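A few compounds are considered here, and "the series" means these few. Any claim that something is new, unique, unknown or untested is made for them only; others in the source may bear on it.

Compound 1 `O=C(OCCO)OCCc1ccc(O)c(O)c1` has no usable entry in an ADME assay on MRC5 cells (Homo sapiens) for inhibition, read by MTT assay, with a stated time of 72 h (on this read-out higher numbers stand for weaker inhibition and lower numbers for stronger inhibition), where compound 1 reads "not determined" (no result reported). Compound 2 `O=C(OCCCCCCCCO)OCCc1ccc(O)c(O)c1` gives > 50000 nM in this assay, which is a limit and not a number. Among the compounds with values here, no measured step is available to calibrate the next change. Compound 3 `CCCCCCCCCCCCCCOC(=O)OCCc1ccc(O)c(O)c1` carries hexyl in place of hydroxy on a saturated chain carbon, eight bonds along the chain from an oxygen next to a carbonyl group. A modest shift towards stronger inhibition is expected, with the estimated step of an at least 1.4-fold lower number from compound 2 to compound 3 (0.15 log units; that floor lies within the scatter). For compound 3 the expected value is 35000 nM, with an estimated range of 10000 nM to 100000 nM.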

Compound 3, half-maximal inhibitory concentration: 9100 nM
Estimate against measurement, compound 3: 3.8-fold (0.59 log units) above; measured number outside the range, below it.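

Within the data shown here, at this position, on a saturated chain carbon, eight bonds along the chain from an oxygen next to a carbonyl group, hexyl in place of hydroxy gives the first single number in this assay, with an at least 5.4-fold lower number from compound 2 to compound 3 (0.73 log units; beyond the scatter) as the change. The full size of this step cannot be read, because compound 2 is recorded only as a limit: the limit of > 50000 nM in this assay, at which 1 of the 3 values shown sits.

Going by these compounds, the separate roles of losing hydroxy and adding carbon remain open. An amine or carboxylic acid at this place, or a longer chain, would test how far the step extends.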